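Aryl Replacement on the Biaryl Tail of Compound 1

The compounds below may be only part of what the source reports. "The series", "measured", "known", "first", "only" and "open" are said of these compounds alone.

compound 1 `CCC(C)(C)Cc1c[nH]c(CCc2ccc(-c3cccc(C)n3)cc2)n1`: 19 nM
compound 2 `CCC(C)(C)Cc1c[nH]c(CCc2ccc(-c3cnsc3)cc2)n1`: 6.9 nM

In a functional assay on HEK293 cells for agonist activity at Bombesin receptor subtype-3 (Mus musculus), read by luminescence and calcium flux, with a stated time of 10 min (on this read-out higher numbers stand for an effect only at larger amounts of compound and lower numbers for an effect already at smaller amounts), compound 1 stands at the highest of the two numbers; compound 2 gives the lower one, a step of a 2.8-fold lower number from compound 1 to compound 2 (0.44 log units; beyond the scatter). Compound 3 `CCC(C)(C)Cc1c[nH]c(CCc2ccc(-c3cccnc3)cc2)n1` differs from compound 1 in one place: pyridin-3-yl in place of 6-methylpyridin-2-yl on an aromatic carbon. Going by the values given here, only the step from compound 1 to compound 2 bears on this change; it swaps a different group in at the same place, and it was modest though beyond the scatter. For compound 3 a step in the same direction, at most as large and possibly within the scatter, is expected, a 1.6-fold lower number from compound 1 to compound 3 (0.20 log units; within the scatter). Compound 3 is estimated at 12 nM, with a range from 4 nM to 40 nM.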

Compound 3, half-maximal effective concentration: 4.3 nM
Compound 3: the middle estimate sits 2.8-fold (0.45 log units) above what was measured; measured number inside the range.
By their numbers in this assay, from the lowest: compounds 3 and 2 (each within the scatter of the next); then compound 1.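

In this assay, a second, different aryl group at this aromatic carbon also lowers the number, a 4.4-fold lower number from compound 1 to compound 3 (0.65 log units; beyond the scatter), so the lowering is not particular to 1,2-thiazol-4-yl. The two replacements are not separated, with a 1.6-fold lower number from compound 2 to compound 3 (0.21 log units; within the scatter). Nothing available accounts for either step. The change from 6-methylpyridin-2-yl to pyridin-3-yl removes the methyl and moves the ring nitrogen together, and the compounds shown do not separate these two changes. Also open, from the compounds shown here alone, is how a group carrying an amine or a carboxylic acid would read at this position.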